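From a Methoxyphenyl Ring to a Furan Ring

The compounds below may be only part of what the source reports. "The series", "measured", "known", "first", "only" and "open" are said of these compounds alone.

Two measured compounds share one core and differ only in the ring attached to the carbon with a double bond to nitrogen. Compound 1 `Cn1c(=O)c(=O)n(C2CCCC2)c2nc(N/N=C/c3ccc(Cl)cc3)ncc21` carries a 4-chlorophenyl group there, and compound 2 `COc1cccc(/C=N/Nc2ncc3c(n2)n(C2CCCC2)c(=O)c(=O)n3C)c1` carries a 3-methoxyphenyl group. In a functional assay on PC-3 cells (Homo sapiens) for antiproliferative activity, read by MTT assay (a lower number here means a stronger inhibitor, a higher number a weaker inhibitor), compound 1 gives 8420 nM, and compound 2 gives 20700 nM. The step of a 2.5-fold higher number from compound 1 to compound 2 (0.39 log units; beyond the scatter) leaves compound 2 with the higher of the two numbers, so among these two it is the weaker inhibitor.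

Compound 3 `Cn1c(=O)c(=O)n(C2CCCC2)c2nc(N/N=C/c3ccco3)ncc21` is not yet measured. It differs from compound 2 in one place: furan-2-yl in place of 3-methoxyphenyl on a carbon with a double bond to nitrogen. Among the compounds with values here, no measured step covers an exchange of a six-membered ring for a five-membered one; the only step known, a 2.5-fold higher number from compound 1 to compound 2 (0.39 log units; beyond the scatter), concerns two six-membered rings and was modest. There is thus little ground for expecting a large move in this assay in either direction. For compound 3 the expected value is 15000 nM, within a range from 5000 nM to 45000 nM. That estimate amounts to an expected step of a 1.4-fold lower number from compound 2 to compound 3 (0.14 log units; within the scatter), which is expected to stay within the usual scatter.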

Compound 3, half-maximal inhibitory concentration: 72200 nM
Compound 3: middle estimate off by 4.8-fold (0.68 log units), on the low side; the whole stated range lies below it.
By their numbers in this assay, from the lowest: compound 1; then compound 2; then compound 3.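

Replacing the 3-methoxyphenyl group with furan-2-yl gives a 3.5-fold higher number from compound 2 to compound 3 (0.54 log units; beyond the scatter) in this assay, and replacing the 4-chlorophenyl group with furan-2-yl gives an 8.6-fold higher number from compound 1 to compound 3 (0.93 log units; beyond the scatter). Within the data shown here, until now, the only comparison at this place involved two six-membered rings, whereas this five-membered ring, with fewer heavy atoms, gives the highest number of the three and therefore the weakest inhibitor, so activity here clearly depends on which ring is attached. No separate measurement is available to explain this loss of activity.

The furan-2-yl group differs from both six-membered groups in ring size and in having an oxygen atom within the ring, so these three compounds cannot show which of those two differences matters. As far as these compounds go, a thiophene ring would keep the five-membered size with sulfur in place of the ring oxygen, a pyridine ring would put a nitrogen atom into a six-membered ring, and it remains open whether either would give a lower number than compound 1 at 8420 nM.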